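The source may report more compounds than this note shows. Statements on the series, on what has been measured and on what is new or still open speak of the compounds shown alone.

The measured compounds:
Compound 1, `Cc1ccc(-c2cc(N3CCC(CNS(N)(=O)=O)CC3)ncn2)cc1`: in a functional assay on MCF7 cells (Homo sapiens) for antiproliferative activity, read by sulforhodamine B assay, with a stated time of 48 h (a higher number here means a weaker inhibitor of growth, a lower number a stronger inhibitor of growth), compound 1 gives 30600 nM.
Compound 2, `CC(C)(C)c1ccc(-c2cc(N3CCC(CNS(N)(=O)=O)CC3)ncn2)cc1`: in this assay compound 2 gives 19700 nM.
Compound 3, `NS(=O)(=O)NCC1CCN(c2cc(-c3ccc(Cl)cc3)ncn2)CC1`: in this assay compound 3 gives 25500 nM.

Compound 2 has the lowest of the three numbers in this assay, but its separation from the others is small: a 1.3-fold higher number from compound 2 to compound 3 (0.11 log units; within the scatter), and a 1.6-fold lower number from compound 1 to compound 2 (0.19 log units; within the scatter), both within the scatter. The three compounds share one core and differ only in the group on the aromatic carbon.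

Compound 4, `CCOC(=O)c1ccc(-c2cc(N3CCC(CNS(N)(=O)=O)CC3)ncn2)cc1`, has not been measured. It differs from compound 2 in one place: ethoxycarbonyl in place of tert-butyl on an aromatic carbon. Going by the values given here, the steps that bear on this change are the two that also swap the group on that aromatic carbon, namely a 1.6-fold lower number from compound 1 to compound 2 (0.19 log units; within the scatter) and a 1.3-fold higher number from compound 2 to compound 3 (0.11 log units; within the scatter); a third, a 1.2-fold lower number from compound 1 to compound 3 (0.08 log units; within the scatter), is of the same kind. None of them moved the number beyond the scatter. On this evidence alone, an ethoxycarbonyl in place of tert-butyl is expected to give no step beyond the scatter either, so compound 4 is expected at a 1.3-fold higher number from compound 2 to compound 4 (0.12 log units; within the scatter). The estimate for compound 4 in this assay is 26000 nM, with a range from 11000 nM to 60000 nM.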

Compound 4, concentration for 50% growth inhibition: 4100 nM
Compound 4: middle estimate off by 6.3-fold (0.80 log units), on the high side, and the stated range ends above it.
By their numbers in this assay, from the lowest: compound 4; then compounds 2, 3 and 1 (each within the scatter of the next).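

In this assay, this position proves sensitive to the group it carries: ethoxycarbonyl gives a 4.8-fold lower number from compound 2 to compound 4 (0.68 log units; beyond the scatter) and a 6.2-fold lower number from compound 3 to compound 4 (0.79 log units; beyond the scatter) as well as a 7.5-fold lower number from compound 1 to compound 4 (0.87 log units; beyond the scatter) in the same comparison. The earlier swaps among methyl, tert-butyl and chloro had stayed within the scatter, so they gave no sign that this aromatic carbon could move the number at all, whereas each of the three steps to ethoxycarbonyl lies beyond it. The change from tert-butyl swaps a group of carbon alone for one of similar size, by heavy-atom count, that carries two oxygens, a double bond and hydrogen-bond acceptors, but nothing available ties the gain in growth inhibition to any one of these features or explains it. The compounds shown leave open whether the effect belongs to the ethoxycarbonyl group specifically or would also appear with a carboxylic acid, an amide, a methoxycarbonyl or a nitrile on this carbon. They also leave open whether a longer ester chain would lower the number further or return it to the level of the other three compounds.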